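This account rests on a few compounds, and the source may have more. Where it says the series, first, only, none or still open, it means among the compounds named here.

Measured so far:
- compound 1 `CCN(Cc1ccc(C)s1)C(=O)COc1ccc(C)cc1` — 178 nM
- compound 2 `Cc1ccc(OCC(=O)N(Cc2cccs2)c2c[nH]nc2C)cc1` — 0.4 nM

Both compounds were tested in an assay on HEK293 cells for agonist activity at transient receptor potential cation channel subfamily M member 8 (Homo sapiens), read by fluorescence and calcium flux, with a stated time of 15 min; a lower number here means that less compound is needed, a higher number that more compound is needed for the effect. Compound 1 gives 178 nM there, while compound 2 gives 0.4 nM. Of the two numbers, compound 2 has the lower one, and the gap to compound 1 is far beyond the usual scatter of the measurement. Among the measured compounds shown here, the two compounds differ in more than one place, so no single step can be read from their values; they show only that compound 2 needs far less material for the same effect.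

Compound 3 `Cc1ccc(OCC(=O)N(Cc2cccs2)c2c(C)n[nH]c2C)cc1` is the next compound, not yet measured. Compared with compound 2 the change is small: methyl in place of hydrogen on an aromatic carbon. For the measured compounds named here, no measured pair in this set shows what such a change does, so there is no step to lean on.

A change of this size is expected to give a 2.5-fold higher number from compound 2 to compound 3 (0.40 log units; beyond the scatter), a step no larger than the scatter or only slightly beyond it. For compound 3 in this assay the estimate is 1 nM, with a range from 0.3 nM to 4 nM.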

Compound 3, half-maximal effective concentration: 0.3 nM
Beside the measured number, compound 3's estimate is 3.3-fold (0.52 log units) above it; measured number inside the range.
By their numbers in this assay, from the lowest: compounds 3 and 2 (each within the scatter of the next); then compound 1.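

In this assay, adding one methyl to the aromatic carbon next to the ring nitrogen, which turns 3-methyl-1H-pyrazol-4-yl into 3,5-dimethyl-1H-pyrazol-4-yl, gives a 1.3-fold lower number from compound 2 to compound 3 (0.12 log units; within the scatter), so the two compounds cannot be told apart in this measurement. This position therefore accepts a methyl with no measurable cost: compound 2 at 0.4 nM and compound 3 at 0.3 nM read as the same result, which the earlier comparison of compound 1 and compound 2 could not show because those two differ in more than one place. No measurement at hand explains why the added methyl leaves the number within the scatter.

Going by these compounds, a single methyl says little about larger or different groups, so it remains open whether an ethyl, a chlorine, an amine or a carboxylic acid on the same carbon would be accepted as well. Also open, on these data alone, is how a plain 1H-pyrazol-4-yl group, carrying no methyl at all, would compare with compound 2 and compound 3.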